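Chloro in Place of Methoxy: Solubility in Two Series

A few compounds are considered here, and "the series" means these few. Any claim that something is new, unique, unknown or untested is made for them only; others in the source may bear on it.

Compound 1, `COc1ccc2[nH]c(C)c(Br)c(=O)c2c1`: in a physicochemical assay for solubility, read by HPLC, at pH 7.4 (a lower number here means a less soluble compound, a higher number a more soluble compound), compound 1 gives > 20000 nM, which is a limit of the assay.
Compound 2, `Cc1[nH]c2ccc(Cl)cc2c(=O)c1Br`: in this assay compound 2 gives 5000 nM.
Compound 3, `COc1cccc2c(=O)c(Cc3ccccc3)c(C)[nH]c12`: in this assay compound 3 gives > 20000 nM, again a limit of the assay.

Compound 2 differs from compound 1 by chloro in place of methoxy on an aromatic carbon. That change brought an at least 4.0-fold lower number from compound 1 to compound 2 (0.60 log units; beyond the scatter). Compound 3 sits at the limit of > 20000 nM in this assay, at which 2 of the 3 values shown sit. How the core of compound 3 differs from that of compound 1 is not broken down here. Compound 4, `Cc1[nH]c2c(Cl)cccc2c(=O)c1Cc1ccccc1`, differs from compound 3 by chloro in place of methoxy on an aromatic carbon. The two places are not the same, so this is the same kind of change, not the same change. For compound 4 the expected step is an at least 3.3-fold lower number from compound 3 to compound 4 (0.52 log units; beyond the scatter), resting on an at least 4.0-fold lower number from compound 1 to compound 2 (0.60 log units; beyond the scatter). Compound 4 is estimated to give 6000 nM, with a range from 1500 nM to 20000 nM.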

Compound 4, solubility: 5000 nM
For compound 4 the middle estimate is 1.2-fold (0.08 log units) above the measured one; measured number inside the range.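

In this assay chloro in place of methoxy goes with an at least 4.0-fold lower number from compound 3 to compound 4 (0.60 log units; beyond the scatter) and also with an at least 4.0-fold lower number from compound 1 to compound 2 (0.60 log units; beyond the scatter) on the other core, so the number falls on both cores, although the change sits at a different place on each. Compound 3 gives > 20000 nM here, which is a limit of the assay. The full size of each step stays unknown, and the two cannot be called equal, because both steps start from a limit: the limit of > 20000 nM in this assay, at which 2 of the 4 values shown sit.

Among the compounds shown here, only two pairs bear on this change, which is too few to make a rule for the series. As far as these compounds go, how an amine or a carboxylic acid in place of the methoxy would read in this assay remains open.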